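Swapping Chloro for Nitro in Compound 1

The source may hold more compounds than are shown below. What is called first, only, known or untested is meant among the compounds shown, and "the series" means these compounds.

Compound 1 `COc1cc(OC)c(OC)cc1/C=C/C(=O)c1ccc(Cl)cc1`: 58500 nM
Compound 2 `COc1cc(OC)c(OC)cc1/C=C/C(=O)c1cc(O)ccc1O`: > 150000 nM (a limit of the assay)

For the measured compounds named here, in a functional assay on SW982 cells (Homo sapiens) for inhibition, read by MTT assay, with a stated time of 72 h (on this read-out lower numbers stand for stronger inhibition and higher numbers for weaker inhibition), compound 1 gives 58500 nM, the only exact number available so far. The result for compound 2 is a limit of the assay, not a number.

Compound 3 `COc1cc(OC)c(OC)cc1/C=C/C(=O)c1ccc([N+](=O)[O-])cc1` has not yet been measured. It differs from compound 1 in one place, with nitro in place of chloro on an aromatic carbon, para to a large group: nitro in place of chloro on an aromatic carbon.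

Going by the values given here, one measured step bears on this change, though only indirectly: an at least 2.5-fold higher number from compound 1 to compound 2 (0.40 log units; beyond the scatter). There, 2,5-dihydroxyphenyl replaces 4-chlorophenyl on a carbonyl carbon, so the same part of compound 1 is altered, but no nitro group is involved. That step gives no direction for the exchange in compound 3, so no shift beyond the scatter is expected in this assay. The estimated step is a 1.1-fold lower number from compound 1 to compound 3 (0.03 log units; within the scatter). For compound 3 the expected value is 55000 nM, with an estimated range from 22000 nM to 130000 nM.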

Compound 3, half-maximal inhibitory concentration: > 150000 nM
Compound 3: only a limit was reported (the forecaster's own chance of this, stated with the estimate: 15%); middle value at least 2.7-fold (0.43 log units) from the limit.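

In this assay, exchanging chloro for nitro on the aromatic carbon para to a large group gives an at least 2.5-fold higher number from compound 1 to compound 3 (0.40 log units; beyond the scatter). This shows that a change at this one position, with the rest of compound 1 left intact, is enough to move the result beyond the scatter and out of the range that gives an exact number, whereas compound 2 had carried a different substitution pattern on that ring and could not isolate this position. The printed step is only a minimum, and the true size of the change from chloro to nitro cannot be read because compound 3 gives a limit rather than a number: the limit of > 150000 nM in this assay, at which 2 of the 3 values shown sit.

The compounds shown leave open whether a fluoro, a bromo, an amine or a carboxylic acid on this same aromatic carbon would give an exact number in this assay, or whether chloro is alone in doing so. They also leave open whether the exchange of chloro for nitro would have the same direction if the rest of compound 1 were altered.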